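Swapping 2,4-difluorophenyl for 4-chlorophenyl on the sulfonyl sulfur

The source may hold more compounds than are shown below. What is called first, only, known or untested is meant among the compounds shown, and "the series" means these compounds.

Compound 1 `Cn1c(=O)c(S(=O)(=O)c2ccccc2)cc2cnc(Nc3cnc4[nH]ccc4c3)nc21`: 5000 nM
Compound 2 `Cn1c(=O)c(S(=O)(=O)c2ccc(F)cc2F)cc2cnc(Nc3cnc4[nH]ccc4c3)nc21`: 750 nM

Both values come from a functional assay on K562 cells (Homo sapiens) for inhibition, read by trypan blue exclusion, with a stated time of 72 h (a lower number here means a stronger inhibitor, a higher number a weaker inhibitor), where compound 2 holds the lower of the two numbers. Compound 3 `Cn1c(=O)c(S(=O)(=O)c2ccc(Cl)cc2)cc2cnc(Nc3cnc4[nH]ccc4c3)nc21` has not yet been measured. It differs from compound 2 as follows: 4-chlorophenyl in place of 2,4-difluorophenyl on a sulfonyl sulfur. For the measured compounds named here, only one measured step bears on this change: a 6.7-fold lower number from compound 1 to compound 2 (0.82 log units; beyond the scatter). Going by the values given here, that step introduced the 2,4-difluorophenyl that now leaves, and no measured compound carries chlorine, so a partial return towards the higher number is expected. The expected step is a 2.0-fold higher number from compound 2 to compound 3 (0.30 log units; within the scatter). In this assay the estimated value for compound 3 is 1500 nM, with an expected range of 400 nM to 5000 nM.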

Compound 3, half-maximal inhibitory concentration: 5000 nM
Compound 3: the middle estimate sits 3.3-fold (0.52 log units) below what was measured, and the stated range covers the measured number.
By their numbers in this assay, from the lowest: compound 2; then compounds 1 and 3 (each within the scatter of the next).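

In this assay, the change on the sulfonyl sulfur gives a 6.7-fold higher number from compound 2 to compound 3 (0.82 log units; beyond the scatter) and shows that the lower number does not survive every substitution of the phenyl. Chloro in place of hydrogen on an aromatic carbon gives no change at the digits printed from compound 1 to compound 3 (within the scatter) and so leaves 4-chlorophenyl level with phenyl, making 2,4-difluorophenyl the only group here that moves the number. Nothing available explains this difference between the two groups. On these data alone, whether a phenyl carrying a single fluorine would keep the lower number remains open. So does the outcome with a methoxy group or an amine on that phenyl.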